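Swapping the methylphenyl arm of compound 1 for pyridinyl

The source may report more compounds than this note shows. Statements on the series, on what has been measured and on what is new or still open speak of the compounds shown alone.

Compound 1 `Cc1ccccc1-c1c(C)nn(-c2nc(-c3ccc(Cl)c(Cl)c3)c(SC(C)C)s2)c1C(=O)O` was tested in a functional assay on BJAB cells (Homo sapiens) for antiproliferative activity, with a stated time of 4 days (a higher number here means that more compound is needed for the effect, a lower number that less compound is needed), where compound 1 gives 5500 nM. Among the three measured compounds it stands second highest: compound 2 `Cc1cc(-c2c(C)nn(-c3nc(-c4ccc(Cl)c(Cl)c4)c(SC(C)C)s3)c2C(=O)O)cc(C)n1` gives 580 nM, and compound 3 `CNc1cc(-c2c(C)nn(-c3nc(-c4ccc(Cl)c(Cl)c4)c(SC(C)C)s3)c2C(=O)O)ccn1` gives 18000 nM. Compound 4 `Cc1nn(-c2nc(-c3ccc(Cl)c(Cl)c3)c(SC(C)C)s2)c(C(=O)O)c1-c1cccnc1` has not yet been measured; it differs from compound 1 in one place: pyridin-3-yl in place of 2-methylphenyl on an aromatic carbon.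

Two measured steps start from compound 1 and exchange the same group. The step to the dimethylpyridinyl ring gave a 9.5-fold lower number from compound 1 to compound 2 (0.98 log units; beyond the scatter), whereas the step to the methylaminopyridinyl ring gave a 3.3-fold higher number from compound 1 to compound 3 (0.51 log units; beyond the scatter), and between those two rings the gap was a 31-fold higher number from compound 2 to compound 3 (1.49 log units; beyond the scatter). Both replacements bring in a pyridinyl ring, yet they pulled in opposite directions, so the direction for compound 4 is uncertain; the ring entering here carries neither methyl nor methylamino, a case without a measured parallel. A modest move in either direction, or none beyond the scatter, seems plausible. The expected step is a 1.8-fold lower number from compound 1 to compound 4 (0.26 log units; within the scatter). For compound 4 the estimate is 3000 nM, with a range from 700 nM to 13000 nM.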

Compound 4, half-maximal effective concentration: 12000 nM
Beside the measured number, compound 4's estimate is 4.0-fold (0.60 log units) below it, within the range that was stated.
By their numbers in this assay, from the lowest: compound 2; then compound 1; then compounds 4 and 3 (each within the scatter of the next).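

Putting pyridin-3-yl on this aromatic carbon gave a 2.2-fold higher number from compound 1 to compound 4 (0.34 log units; beyond the scatter), so a ring nitrogen in place of the 2-methylphenyl ring does not by itself bring the number down. The comparison with the methylaminopyridinyl ring gave a 1.5-fold lower number from compound 3 to compound 4 (0.18 log units; within the scatter), which leaves those two rings unseparated here. Only the 2,6-dimethylpyridin-4-yl ring stands apart, with a 21-fold higher number from compound 2 to compound 4 (1.32 log units; beyond the scatter), so among the three pyridinyl rings shown the lower number belongs to that ring alone.

Nothing measured here accounts for that gap. Still open, going by these compounds, is whether a single methyl on the pyridinyl ring would be enough, and whether a methoxy group or a chlorine in place of those methyls would give a similar number.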